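Aryl acid replacement in a glutamate receptor modulator series

The source may report more compounds than this note shows. Statements on the series, on what has been measured and on what is new or still open speak of the compounds shown alone.

Compound 1 `Cc1c(OCCCCOc2ccc(C(=O)O)cc2Cl)ccc(C(=O)CC2CCCC2)c1O`: 237 nM
Compound 2 `COc1ccc(C(=O)O)cc1OCCCCOc1ccc(C(=O)CC2CCCC2)c(O)c1C`: 425 nM
Compound 3 `COC(=O)c1ccc(OCCCCOc2ccc(C(=O)CC3CCCC3)c(O)c2C)cc1`: "not determined" (no result reported)

The three measured compounds share a core and differ only in the aryl group carried on an oxygen on a saturated carbon. In an assay on HEK293 cells for positive allosteric modulation of metabotropic glutamate receptor 2 (Rattus norvegicus), read by thallium flux, with a stated time of 2.5 min (a lower number here means that less compound is needed, a higher number that more compound is needed for the effect), compound 1 gives 237 nM and compound 2 gives 425 nM. The step of a 1.8-fold higher number from compound 1 to compound 2 (0.25 log units; within the scatter) exchanges one carboxy-bearing aryl group for another and stays within the scatter. Compound 3 stands apart: in this assay compound 3 gives "not determined" (no result reported), so no number places it relative to compound 1 or compound 2.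

Compound 4 `Cc1ccc(C(=O)O)cc1OCCCCOc1ccc(C(=O)CC2CCCC2)c(O)c1C` is the unmeasured member. The change from compound 3 is 5-carboxy-2-methylphenyl in place of 4-(methoxycarbonyl)phenyl on an oxygen on a saturated carbon. For the measured compounds named here, no measured step covers this exchange directly, since compound 3 has no number. What bears on it is the behaviour of compound 1 and compound 2, both of which carry a carboxy-bearing aryl group at the same place, and whose step was within the scatter. Compound 4 carries a carboxy-bearing aryl group there too, so it is expected to land near those two in this assay. Compound 4 is therefore estimated at 330 nM, with a range from 120 nM to 1000 nM.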

Compound 4, half-maximal effective concentration: 1290 nM
Compound 4: middle estimate off by 3.9-fold (0.59 log units), on the low side, and the stated range ends below it.
By their numbers in this assay, from the lowest: compounds 1 and 2 (each within the scatter of the next); then compound 4.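

In this assay, a carboxy-bearing aryl group on the oxygen does not by itself hold the number in the range of compound 1 and compound 2. Methyl in place of methoxy on an aromatic carbon gives a 3.0-fold higher number from compound 2 to compound 4 (0.48 log units; beyond the scatter), a modest change but one that lies beyond the scatter, so this small substituent matters even with the carboxy group kept in the same place. The exchange of 4-carboxy-2-chlorophenyl for 5-carboxy-2-methylphenyl gives a 5.4-fold higher number from compound 1 to compound 4 (0.74 log units; beyond the scatter), which is also modest, and nothing available explains either step.

Going by these compounds, with only methoxy and methyl compared directly on this aryl group, it remains open whether an ethoxy group, a chlorine or a plain hydrogen at that place would bring the number back towards that of compound 2 or move it further away. On these data alone, compound 3 has no number to set against compound 4, so what the methyl ester of 4-(methoxycarbonyl)phenyl does here stays unknown, as does whether a tetrazole could stand in for the carboxylic acid.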